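Replacing the furan ester with a hydroxypentyl chain

The source may report more compounds than this note shows. Statements on the series, on what has been measured and on what is new or still open speak of the compounds shown alone.

Of the compounds shown here, three built on one shared core have been tested in a functional assay on HeLa cells (Homo sapiens) for cytotoxicity, read by MTT assay; on this read-out higher numbers stand for weaker inhibition and lower numbers for stronger inhibition. Compound 1 `CCCCC(O)CC(=O)O[C@H](CC=C(C)C)C1=CC(=O)c2c(O)ccc(O)c2C1=O` gives 72200 nM in this assay. Compound 3 `COC(C)CO[C@H](CC=C(C)C)C1=CC(=O)c2c(O)ccc(O)c2C1=O` gives 53400 nM, and the step of a 1.4-fold lower number from compound 1 to compound 3 (0.13 log units; within the scatter) lies within the scatter. Compound 2 `CC(C)=CC[C@@H](OC(=O)c1ccoc1)C1=CC(=O)c2c(O)ccc(O)c2C1=O` reaches only the limit of this assay, > 100000 nM. Compound 2 therefore stands at the edge of what this assay can record, as shown by the limit of > 100000 nM in this assay, at which 1 of the 3 values shown sits, so its true number is not known, only that it lies beyond that mark.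

Compound 4 `CCCC(O)CC(=O)O[C@H](CC=C(C)C)C1=CC(=O)c2c(O)ccc(O)c2C1=O` is not yet measured. It differs from compound 2 in one place: 2-hydroxypentyl in place of furan-3-yl on a carbonyl carbon. The entering chain closely resembles the 2-hydroxyhexyl chain of compound 1.

Among the compounds with values here, two measured steps bear on this change. The reverse replacement, an at least 1.3-fold higher number from compound 1 to compound 2 (0.14 log units; that floor lies within the scatter), moved the number up to the limit. The step of an at least 1.8-fold lower number from compound 2 to compound 3 (0.27 log units; that floor lies within the scatter) also runs from the furan ester to a lower number. Both are floors that sit within the scatter, so the step from compound 2 to compound 4 is expected to be a modest move to a lower number, roughly undoing the first of these, estimated as an at least 1.2-fold lower number from compound 2 to compound 4 (0.09 log units; that floor lies within the scatter). Compound 4 is therefore expected to give about 80000 nM, likely between 40000 nM and 160000 nM.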

Compound 4, half-maximal inhibitory concentration: 59300 nM
The estimate for compound 4 lay 1.3-fold (0.13 log units) above the measured number; the measured number falls inside the stated range.
By their numbers in this assay, from the lowest: compounds 3, 4 and 1 (each within the scatter of the next). At a limit, above all of these: compound 2.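

Within the data shown here, compound 2 remains the only compound here without a true number in this assay: the limit of > 100000 nM in this assay, at which 1 of the 4 values shown sits. Placing 2-hydroxypentyl on the carbonyl carbon in place of furan-3-yl gives a measured number rather than a limit, and the step of an at least 1.6-fold lower number from compound 2 to compound 4 (0.22 log units; that floor lies within the scatter) is only a floor, so the real size of this change could be larger than what is printed. The other two steps show that this position tolerates more than one kind of chain without a readable change: swapping a methyl for hydrogen on the hydroxy chain gives a 1.2-fold lower number from compound 1 to compound 4 (0.09 log units; within the scatter), and exchanging the 2-methoxypropyl group for the (2-hydroxypentyl)carbonyl group gives a 1.1-fold higher number from compound 3 to compound 4 (0.05 log units; within the scatter), so compounds 1, 3 and 4 cannot be told apart in this assay.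

Going by these compounds, the true number of compound 2 stays unknown, and with it the full size of any step away from furan-3-yl. Also open, on these data alone, is whether an amine, a carboxylic acid or a longer chain in place of 2-hydroxypentyl on the carbonyl carbon would move the number beyond the scatter in either direction.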